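The compounds below may be only part of what the source reports. "The series", "measured", "known", "first", "only" and "open" are said of these compounds alone.

Compound 3, `OC[C@H]1O[C@@H](n2cnc3c(CSc4c(F)cccc4Cl)ncnc32)[C@H](O)[C@@H]1O`, gives 1510 nM in an assay on isolated protein for binding affinity to Equilibrative nucleoside transporter 1 (Homo sapiens); on this read-out lower numbers stand for stronger inhibition and higher numbers for weaker inhibition. Compound 1, `CCCCCNc1ncnc2c1ncn2[C@@H]1O[C@H](CO)[C@@H](O)[C@H]1O`, gives 13500 nM. Compound 2, `OC[C@H]1O[C@@H](n2cnc3c(Sc4ccccc4)ncnc32)[C@H](O)[C@@H]1O`, gives 91200 nM.

Compound 3 has the lowest number of the three, below compound 1 and far below compound 2. Compound 4, `OC[C@H]1O[C@@H](n2cnc3c(CSc4ccc(Br)cc4)ncnc32)[C@H](O)[C@@H]1O`, differs from compound 3 in one place: 4-bromophenyl in place of 2-chloro-6-fluorophenyl on a sulfur. Within the data shown here, the only measured step, a 6.8-fold higher number from compound 1 to compound 2 (0.83 log units; beyond the scatter), changes the group on the aromatic carbon of the core and not the group on the sulfur, so no measured step bears directly on this change. With nothing to point either way, compound 4 is expected to stay near compound 3 in this assay, with a step of a 1.7-fold higher number from compound 3 to compound 4 (0.22 log units; within the scatter) that is estimated to remain within the scatter. Compound 4 is therefore estimated at 2500 nM, within 700 nM to 9000 nM.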

Compound 4, half-maximal inhibitory concentration: 178 nM
For compound 4 the middle estimate is 14-fold (1.15 log units) above the measured one; the measured number lies below the stated range.
By their numbers in this assay, from the lowest: compound 4; then compound 3; then compound 1; then compound 2.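

In this assay, among these compounds, the group on the sulfur proves to matter: 4-bromophenyl in place of 2-chloro-6-fluorophenyl gives an 8.5-fold lower number from compound 3 to compound 4 (0.93 log units; beyond the scatter) with only that group changed. Exchanging the whole group on the aromatic carbon for ((4-bromophenyl)sulfanyl)methyl gives a 510-fold lower number from compound 2 to compound 4 (2.71 log units; beyond the scatter) and also a 76-fold lower number from compound 1 to compound 4 (1.88 log units; beyond the scatter) on the same position of the shared core. Nothing available here explains these steps.

Still open, going by these compounds, is whether the bromine alone carries the step from the 2-chloro-6-fluorophenyl group. A plain phenyl, a 4-chlorophenyl or a 4-aminophenyl on the same sulfur would bear on that question.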